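Phenyl to 4-fluorophenyl on a poorly active amide

This account rests on a few compounds, and the source may have more. Where it says the series, first, only, none or still open, it means among the compounds named here.

In a functional assay on MDA-MB-231 cells (Homo sapiens), read by microscopy and transwell migration, with a stated time of 24 h (a higher number here means a weaker inhibitor, a lower number a stronger inhibitor), the measured compounds are:
- Compound 1 `CCCCCCCCCCCCn1c(-c2ccc(C)cc2C)cs/c1=N\C(=O)c1ccccc1` gives 24 nM
- Compound 2 `O=C(Nc1nc(-c2cccc(Br)c2)cs1)c1ccccc1` gives 10000 nM
- Compound 3 `Cc1sc(NC(=O)c2ccccc2)nc1-c1ccccc1` gives > 25000 nM as a limit

Compound 3 has no number in this assay and stands only at the limit (> 25000 nM). Compound 4 `Cc1sc(NC(=O)c2ccccc2)nc1-c1ccc(F)cc1` carries fluoro in place of hydrogen on an aromatic carbon of compound 3, para to a large group (fluoro in place of hydrogen on an aromatic carbon). Among the compounds with values here, no measured pair shows this change, so the expectation is a cautious one. The expected size of the step of an at least 1.2-fold lower number from compound 3 to compound 4 (0.09 log units; that floor lies within the scatter) is small and within the usual scatter, with no clear direction. Compound 4 is estimated at 20000 nM with an expected range (7000 nM to 40000 nM).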

Compound 4, half-maximal inhibitory concentration: 9100 nM
The estimate for compound 4 lay 2.2-fold (0.34 log units) above the measured number; the measured number falls inside the stated range.
By their numbers in this assay, from the lowest: compound 1; then compounds 4 and 2 (each within the scatter of the next). At a limit, above all of these: compound 3.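

In this assay, the change from phenyl to 4-fluorophenyl gives an at least 2.7-fold lower number from compound 3 to compound 4 (0.43 log units; beyond the scatter), the first sign that this place on the aromatic ring responds to a single fluoro. Compound 3 stands only at a limit of the assay, > 25000 nM. The step is therefore a floor, and its true size remains unfixed: the limit of > 25000 nM in this assay, at which 1 of the 4 values shown sits.

The compounds shown leave open whether chloro, methoxy or an amine in the same place would lower the number further. They also leave open whether fluoro would give a similar step in another compound.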